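Swapping the propargyl arm for a benzyloxycarbonyl group

This account rests on a few compounds, and the source may have more. Where it says the series, first, only, none or still open, it means among the compounds named here.

Compound 1 `C#CCn1c2ccc([N+](=O)[O-])cc2c(=O)n1Cc1ccccc1` is the reference point of this small set. Within the data shown here, in an ADME assay on L929 cells (Mus musculus) for cytotoxicity, read by resazurin assay, with a stated time of 48 h (on this read-out lower numbers stand for higher toxicity in this test and higher numbers for lower toxicity in this test), compound 1 gives 195000 nM, the highest number of the three measured so far, meaning it is the least harmful to these cells among them. Compound 2 `COC(=O)Cn1c2ccc([N+](=O)[O-])cc2c(=O)n1Cc1ccccc1` gives 129000 nM in this assay, and compound 3 `CCOC(=O)CCCn1c2ccc([N+](=O)[O-])cc2c(=O)n1Cc1ccccc1` gives 78100 nM. The change from compound 1 to compound 2 produced a 1.5-fold lower number from compound 1 to compound 2 (0.18 log units; within the scatter), while the change from compound 1 to compound 3 produced a 2.5-fold lower number from compound 1 to compound 3 (0.40 log units; beyond the scatter); between the two esters there was a 1.7-fold lower number from compound 2 to compound 3 (0.22 log units; within the scatter).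

Compound 4 `O=C(OCc1ccccc1)n1c2ccc([N+](=O)[O-])cc2c(=O)n1Cc1ccccc1` has not been measured. It differs from compound 1 as follows: benzyloxycarbonyl in place of propargyl on an aromatic nitrogen. All three measured compounds share the same core and the same benzyl group, and both measured steps away from compound 1 replaced the propargyl arm with a chain carrying an ester; both moved the number downward, one within the scatter and one just beyond it. Compound 4 also carries an ester-type group, now attached directly to the ring nitrogen, so a step of similar size in the same direction is expected, and the estimate for compound 4 is 110000 nM, between 45000 nM and 270000 nM, corresponding to an expected step of a 1.8-fold lower number from compound 1 to compound 4 (0.25 log units; within the scatter).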

Compound 4, concentration lethal to 50% of the cells: 86100 nM
Beside the measured number, compound 4's estimate is 1.3-fold (0.11 log units) above it; measured number inside the range.
By their numbers in this assay, from the lowest: compounds 3, 4, 2 and 1 (each within the scatter of the next, the first and the last beyond it).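

Among these compounds, replacing propargyl with the much larger benzyloxycarbonyl group, which brings a six-membered aromatic ring and places a carbonyl on the aromatic nitrogen itself, gives a 2.3-fold lower number from compound 1 to compound 4 (0.36 log units; beyond the scatter); this step, like the one to compound 3 and unlike the one to compound 2, lies beyond the scatter. In this assay, compound 4 cannot be told apart from either compound with an ester-bearing chain, with a 1.1-fold higher number from compound 3 to compound 4 (0.04 log units; within the scatter) and a 1.5-fold lower number from compound 2 to compound 4 (0.18 log units; within the scatter), so neither the added aromatic ring nor the loss of the saturated chain sets compound 4 apart from them. No supporting evidence is available to explain why these different arms give results within the scatter of one another.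

The compounds shown leave open whether an ester-type group is needed at all on this nitrogen, since a plain ethyl group or a longer hydrocarbon chain could reveal whether other arms also give lower numbers than propargyl. They also leave open how a carboxylic acid or an amine at the end of the chain would compare with the esters, and whether any such group would separate clearly from them.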